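This account rests on a few compounds, and the source may have more. Where it says the series, first, only, none or still open, it means among the compounds named here.

Among the compounds with values here, in a functional assay on MDA-MB-231 cells (Homo sapiens) for antiproliferative activity, with a stated time of 4 days (a lower number here means a stronger inhibitor, a higher number a weaker inhibitor), compound 2 `CCCCc1ccc2[nH]c(-c3ccc(OC)cc3)c(/C=N/NC(=O)c3cccc(OC)c3)c2c1` gives 55 nM, the lowest number so far, while compound 1 `CCCCc1ccc2[nH]c(-c3ccc(C(F)(F)F)cc3)c(/C=N/NC(=O)c3ccc(OC)cc3)c2c1` gives 284 nM and compound 3 `CCCCc1ccc2[nH]c(-c3ccc(C(F)(F)F)cc3)c(/C=N/NC(=O)c3ccc([N+](=O)[O-])cc3)c2c1` gives 2040 nM. Compound 4 `CCCCc1ccc2[nH]c(-c3ccc(OC)cc3)c(/C=N/NC(=O)c3ccncc3)c2c1` differs from compound 2 in one place, with pyridin-4-yl in place of 3-methoxyphenyl on a carbonyl carbon. Within the data shown here, only one measured step removes a methoxy group: a 7.2-fold higher number from compound 1 to compound 3 (0.86 log units; beyond the scatter), with nitro in place of methoxy on an aromatic carbon. That is a single step with a different incoming group, so it guides the expectation only loosely. A step of similar size towards a higher number is expected in this assay, a 5.5-fold higher number from compound 2 to compound 4 (0.74 log units; beyond the scatter). For compound 4 the estimated value is 300 nM, within an expected range of 70 nM to 1200 nM.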

Compound 4, half-maximal inhibitory concentration: 29 nM
Estimate against measurement, compound 4: 10-fold (1.01 log units) above; measured number below the stated range.
By their numbers in this assay, from the lowest: compounds 4 and 2 (each within the scatter of the next); then compound 1; then compound 3.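

In this assay, exchanging the 3-methoxyphenyl on the carbonyl carbon for pyridin-4-yl gives a 1.9-fold lower number from compound 2 to compound 4 (0.28 log units; within the scatter), so this position accepts a ring with a hetero atom and no methoxy group without a change beyond the scatter. This is the first step shown at this place with the methoxy-substituted phenyl at the other end of the core, and it differs from a 7.2-fold higher number from compound 1 to compound 3 (0.86 log units; beyond the scatter), which involves a nitro group on a different compound pair. No measured evidence bears on this result. The compounds shown leave open how an amine or a carboxylic acid on this ring would read, and how a saturated ring such as piperidine would read on the same carbonyl carbon.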